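The source may report more compounds than this note shows. Statements on the series, on what has been measured and on what is new or still open speak of the compounds shown alone.

Measured so far:
compound 1 `CCOc1cc2nc(CCC(C)(C)C(=O)NCCOCCOCCNc3cccc4c3C(=O)N(C3CCC(=O)N(C)C3=O)C4=O)n(C)c2cc1NC(=O)c1cccc(C(F)(F)F)n1` with 11000 nM in a functional assay on OCI-Ly10 cells (Homo sapiens) for inhibition, read by CCK-8 assay, with a stated time of 72 h; on this read-out lower numbers stand for stronger inhibition and higher numbers for weaker inhibition;
compound 2 `CCOc1cc2nc(CCC(C)(C)C(=O)OC)n(C)c2cc1NC(=O)c1cccc(C(F)(F)F)n1`, for which this assay reports only a limit, > 50000 nM.

Compound 1 is the only one of the two that gives a number in this assay; compound 2 gives no number, just a limit, and that limit of > 50000 nM in this assay, at which 1 of the 2 values shown sits, is all that can be said of it. Among the compounds with values here, no step between two measured compounds can be read off here, so nothing measured tells how a single change moves the numbers in this set.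

Compound 3 `CCOc1cc2nc(CCC(C)(C)C(=O)NCCOCCOCCNc3cccc4c3C(=O)N(C3CCC(=O)NC3=O)C4=O)n(C)c2cc1NC(=O)c1cccc(C(F)(F)F)n1` differs from compound 1 in one place: hydrogen in place of methyl on an amide-type nitrogen in a ring. Within the data shown here, no measured pair shows this change, so the expectation for it rests on the structural change alone. The step from compound 1 to compound 3 in this assay is expected to be a large one toward stronger inhibition, well beyond the scatter, a 37-fold lower number from compound 1 to compound 3 (1.56 log units; beyond the scatter). On that basis compound 3 is estimated to give about 300 nM in this assay, with a likely range from 50 nM to 3000 nM, though a result within the scatter of compound 1 cannot be ruled out.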

Compound 3, half-maximal inhibitory concentration: 4600 nM
Compound 3: the middle estimate sits 15-fold (1.19 log units) below what was measured; measured number above the stated range.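

In this assay, within the data shown here, the change from the 1-methyl-2,6-dioxopiperidin-3-yl group to the 2,6-dioxopiperidin-3-yl group gives a 2.4-fold lower number from compound 1 to compound 3 (0.38 log units; beyond the scatter) and so provides the first measured reading of this position: swapping methyl for hydrogen on the amide-type nitrogen in the ring does shift the number, though only modestly. The methyl group therefore does not abolish inhibition in this cell assay, since compound 1 still gives a measurable value, and its removal does not bring a large gain, since compound 3 still gives 4600 nM. Nothing measured here points to a cause for this step.

The compounds shown leave open how an ethyl group or another larger group on this same nitrogen would compare with methyl and hydrogen. Among these compounds, they also leave open whether this modest step would keep its size if a longer chain joined the ring system to the rest of the molecule, since only one such pair can be read here.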